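A few compounds are considered here, and "the series" means these few. Any claim that something is new, unique, unknown or untested is made for them only; others in the source may bear on it.

Compound 1, with the structure `C1=NCC(CC2=Cc3ccccc3CC2)N1`, gives 50.1 nM in a functional assay for binding affinity to Norepinephrine transporter (Rattus norvegicus), read by radioligand binding, in the presence of a further agent that is not named here; on this read-out lower numbers stand for stronger inhibition and higher numbers for weaker inhibition. Compound 2, `Cc1cccc2c1C=C(CC1CN=CN1)CC2`, carries one change against it: methyl in place of hydrogen on an aromatic carbon; in this assay compound 2 gives 1000 nM, a step of a 20-fold higher number from compound 1 to compound 2 (1.30 log units; beyond the scatter). Compound 3 has a different core, `NC1=NCC(CC2=Cc3ccccc3CC2)O1`, and the difference between the two cores is not broken down here; in this assay compound 3 gives 1000 nM, level with compound 2 at the digits given. Compound 4, `Cc1ccc2c(c1)CCC(CC1CN=C(N)O1)=C2`, is made from compound 3 by the same kind of change, (methyl in place of hydrogen on an aromatic carbon), though the place differs: here the methyl sits meta to a fused ring and para to a fused ring, whereas in compound 2 it sits ortho to a fused ring and meta to a fused ring. Because the earlier methyl gave a 20-fold higher number from compound 1 to compound 2 (1.30 log units; beyond the scatter), a weakening is expected, though a smaller one: the step from compound 3 to compound 4 is estimated at a 2.5-fold higher number from compound 3 to compound 4 (0.40 log units; beyond the scatter). Compound 4 is expected to give 2500 nM.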

Compound 4, inhibition constant: < 1000 nM
Compound 4 ended at the assay's limit; the forecaster's own chance of this, stated with the estimate: 25%; at least 2.5-fold (0.39 log units) between middle value and limit.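

In this assay compound 4 gives < 1000 nM, which is a limit of the assay and not a number. Methyl in place of hydrogen on an aromatic carbon gives a number no higher from compound 3 to compound 4 (the limit leaves the size open), so the weakening seen on the core of compound 1 did not carry over to the core of compound 3: the same change on two cores in this assay, a 20-fold higher number (1.30 log units; beyond the scatter) from compound 1 to compound 2 and a number no higher (the limit leaves the size open) from compound 3 to compound 4, at least 19-fold (1.30 log units) apart, beyond the scatter of two such steps. This does not show how large the step on the second core is, and the methyl sits at a different place on each core, so one pair per core cannot separate the role of the core from that of the place. Still open, going by these compounds, is what the methyl does at one and the same place on both cores, and how a methoxy group or a chlorine atom would behave in its stead.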